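The source may hold more compounds than are shown below. What is called first, only, known or untested is meant among the compounds shown, and "the series" means these compounds.

Compound 1 `COc1ccc(Cl)cc1C[C@@H]1CN/C(=N\N(C)C)CN(CC(=O)Nc2cccc(S(=O)(=O)N(C)C)c2)C1=O` gives 990 nM in an assay on isolated protein for inhibition of kallikrein-7 (Homo sapiens), read by fluorescence, with stated times of 10 min and 30 min; a higher number here means a weaker inhibitor, a lower number a stronger inhibitor.
Compound 2 `COc1cccc(NC(=O)CN2C/C(=N/N(C)C)NC[C@@H](Cc3cc(Cl)ccc3OC)C2=O)c1` gives 2700 nM in this assay.
Compound 3 `COc1ccc(Cl)cc1C[C@@H]1CN/C(=N\N(C)C)CN(CC(=O)Nc2cccc(-c3ccoc3)c2)C1=O` gives 670 nM in this assay.

Of the three measured compounds, compound 3 carries the lowest number, but its standing is mixed: against compound 2 the gap is clear, a 4.0-fold lower number from compound 2 to compound 3 (0.61 log units; beyond the scatter), whereas against compound 1 the gap is a 1.5-fold lower number from compound 1 to compound 3 (0.17 log units; within the scatter), so compound 1 and compound 3 cannot be told apart on these data. The remaining step, a 2.7-fold higher number from compound 1 to compound 2 (0.44 log units; beyond the scatter), shows that the group on the outer aromatic ring does move the number, within a modest span.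

Compound 4 `COc1ccc(Cl)cc1C[C@@H]1CN/C(=N\N(C)C)CN(CC(=O)Nc2cccc(-c3ccsc3)c2)C1=O` differs from compound 3 in one place: thiophen-3-yl in place of furan-3-yl on an aromatic carbon. Going by the values given here, no measured step exchanges one five-membered heteroaryl for another; the steps that touch this position swap in groups of quite different kinds, and even those move the number only modestly. A change that keeps the ring size, the atom count and the acceptor count is therefore expected to give no step beyond the scatter in this assay, in either direction.

Compound 4 is accordingly estimated at 600 nM, with a likely range from 300 nM to 1300 nM, which means an expected step of a 1.1-fold lower number from compound 3 to compound 4 (0.05 log units; within the scatter).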

Compound 4, half-maximal inhibitory concentration: 1500 nM
Compound 4: middle estimate off by 2.5-fold (0.40 log units), on the low side; the whole stated range lies below it.
By their numbers in this assay, from the lowest: compounds 3, 1, 4 and 2 (each within the scatter of the next, the first and the last beyond it).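

The exchange of one five-membered aromatic ring for another is not neutral at this aromatic carbon in this assay: the step reads a 2.2-fold higher number from compound 3 to compound 4 (0.35 log units; beyond the scatter) even though furan-3-yl and thiophen-3-yl have the same counts of heavy atoms, hetero atoms and hydrogen-bond acceptors, with sulfur entering for oxygen. The earlier steps shown here at this position all exchanged groups of different kinds, while the new compound cannot be separated from either earlier neighbour, with a 1.8-fold lower number from compound 2 to compound 4 (0.26 log units; within the scatter) and a 1.5-fold higher number from compound 1 to compound 4 (0.18 log units; within the scatter) both within the scatter, so of the two rings only furan-3-yl stands clear of methoxy. Nothing available accounts for the difference between the two rings.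

From the compounds shown here alone, it remains open whether the ring's attachment matters, as furan-2-yl or thiophen-2-yl would show, and whether a pyrrole or thiazole ring at the same place would fall with furan-3-yl or with thiophen-3-yl. Going by these compounds, it is also open whether the gap between these two rings holds on a core with a different group in place of the 5-chloro-2-methoxybenzyl side chain.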